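Moving One Hydroxyl Group Weakens Cytotoxicity

The source may report more compounds than this note shows. Statements on the series, on what has been measured and on what is new or still open speak of the compounds shown alone.

Compound 1 `Oc1cccc(-c2cc(-c3ccccc3O)cc(-c3cccc(O)c3)n2)c1` is reported in a functional assay on DU-145 cells (Homo sapiens) for cytotoxicity, read by CCK-8 assay, with a stated time of 4 days (a higher number here means a weaker inhibitor, a lower number a stronger inhibitor), only as a limit: > 50000 nM.
Compound 2 `Oc1cccc(-c2cc(-c3ccccc3O)cc(-c3ccccc3O)n2)c1` gives in this assay 3980 nM.
Compound 3 `Oc1ccc(-c2cc(-c3ccccc3O)nc(-c3ccccc3O)c2)cc1` is reported in this assay only as a limit: > 50000 nM.

Compound 2 is the only one of the three measured compounds that yields a number rather than a limit. Going from compound 2 to compound 1 puts 3-hydroxyphenyl in place of 2-hydroxyphenyl on an aromatic carbon, and the step is an at least 12-fold higher number from compound 2 to compound 1 (1.09 log units; beyond the scatter), a change that carries the value onto (the limit of > 50000 nM in this assay, at which 2 of the 3 values shown sit). The difference between the cores of compound 2 and compound 3 is not broken down here.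

Compound 4 `Oc1ccc(-c2cc(-c3cccc(O)c3)nc(-c3ccccc3O)c2)cc1` has not yet been measured. It differs from compound 3 by the same kind of change (3-hydroxyphenyl in place of 2-hydroxyphenyl on an aromatic carbon), the place being meta to a 4-hydroxyphenyl group rather than meta to a 3-hydroxyphenyl group. With compound 3 already at the limit, the expected step for compound 4 is a step that the limit leaves unreadable from compound 3 to compound 4. Compound 4 is therefore expected to give 80000 nM, most likely reported again only as a limit, somewhere between 30000 nM and 300000 nM.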

Compound 4, half-maximal inhibitory concentration: 3420 nM
Estimate against measurement, compound 4: 23-fold (1.37 log units) above; the whole stated range lies above it.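

The same swap of 2-hydroxyphenyl for 3-hydroxyphenyl does not carry over from one core to the other, since it moves the result in opposite directions: the same change on two cores in this assay, an at least 12-fold higher number (1.09 log units; beyond the scatter) from compound 2 to compound 1 and an at least 14-fold lower number (1.16 log units; beyond the scatter) from compound 3 to compound 4, at least 180-fold (2.26 log units) apart, beyond the scatter of two such steps
In this assay, among these compounds, the new step is an at least 14-fold lower number from compound 3 to compound 4 (1.16 log units; beyond the scatter), and it leaves the result in the same range as the one measured number from before, with a 1.2-fold lower number from compound 2 to compound 4 (0.07 log units; within the scatter).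
This shows that the effect of the swap depends on which other hydroxyphenyl groups the core carries, but it does not show why the direction flips or how large either step truly is, for compound 1 and compound 3 are known only as limits: the limit of > 50000 nM in this assay, at which 2 of the 4 values shown sit.

Going by these compounds, with a single pair on each core, it remains open whether the reversal would hold for any further arrangement of these groups. All the compounds shown carry only hydroxyphenyl groups, so it is also open how a methoxy group or an amine in place of a hydroxyl would behave in this series.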